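Swapping a dichlorophenoxy group for a fluorophenyl sulfide

This account rests on a few compounds, and the source may have more. Where it says the series, first, only, none or still open, it means among the compounds named here.

Among the compounds with values here, in a functional assay on SF-539 cells (Homo sapiens) for inhibition, read by sulforhodamine B assay, with a stated time of 48 h (a higher number here means a weaker inhibitor of growth, a lower number a stronger inhibitor of growth), compound 1 `Nc1cc(N)c2nc(-c3ccccc3)c(Oc3ccc(Cl)c(Cl)c3)nc2c1` gives 29500 nM, the only plain number among the three measured compounds. Compound 2 `CCOC(=O)[C@H](CCC(=O)O)NC(=O)c1ccc(CNc2nc3cc(N)cc(N)c3nc2-c2ccccc2)cc1` gives < 100000 nM, which is a limit of the assay rather than a number. Compound 3 `CCOC(=O)[C@H](CCC(=O)O)NC(=O)c1ccc(Oc2nc3cc(N)cc(N)c3nc2-c2ccccc2)cc1` gives < 100000 nM, again a limit. Two of the three results sit at the limit of < 100000 nM in this assay, at which 2 of the 3 values shown sit, leaving compound 1 as the single fixed point.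

Compound 4 `Nc1cc(N)c2nc(-c3ccccc3)c(Sc3ccc(F)cc3)nc2c1` differs from compound 1 in one place: (4-fluorophenyl)sulfanyl in place of 3,4-dichlorophenoxy on an aromatic carbon. Within the data shown here, no measured pair shows a change of this kind, and the expected step of a 1.4-fold higher number from compound 1 to compound 4 (0.13 log units; within the scatter) is small, toward weaker inhibition, and may not exceed the usual scatter. Compound 4 is expected near 40000 nM, with a range from 10000 nM to 100000 nM.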

Compound 4, concentration for total growth inhibition: 39800 nM
Beside the measured number, compound 4's estimate is 1.0-fold (0.00 log units) above it; measured number inside the range.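

Within the data shown here, at this position, next to the ring nitrogen, (4-fluorophenyl)sulfanyl in place of 3,4-dichlorophenoxy gives the first readable step in this assay: a 1.3-fold higher number from compound 1 to compound 4 (0.13 log units; within the scatter). The swap changes the linking atom and the halogens at once, and a step this small does not show whether either change matters alone. Compound 2 and compound 3 offer no comparison, since their results are limits: the limit of < 100000 nM in this assay, at which 2 of the 4 values shown sit.

Still open, as far as these compounds go, is whether an amine or a carboxylic acid on the phenyl ring here would move growth inhibition beyond the scatter.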